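Trimming Isopropyl to Ethyl in a Weakly Cytotoxic Series

The compounds below may be only part of what the source reports. "The series", "measured", "known", "first", "only" and "open" are said of these compounds alone.

Compound 1 `COc1ccc(CN2CCN(c3nc(Nc4ccc(C#N)c(C(F)(F)F)c4)nc(Oc4ccnc5ccccc45)n3)CC2)c(OC)c1OC` gives > 100000 nM in a functional assay on DU-145 cells (Homo sapiens) for cytotoxicity, read by sulforhodamine B assay, with a stated time of 48 h (on this read-out lower numbers stand for stronger inhibition of growth and higher numbers for weaker inhibition of growth), which is a limit of the assay rather than a number. Compound 2 `CC(C)N1CCN(c2nc(Nc3ccc(C#N)c(C(F)(F)F)c3)nc(Oc3ccnc4ccccc34)n2)CC1` likewise gives > 100000 nM, again a limit. Compound 3 `CC(=O)N1CCN(c2nc(Nc3ccc(C#N)c(C(F)(F)F)c3)nc(Oc3ccnc4ccccc34)n2)CC1` gives 75100 nM.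

Compound 2 therefore stands at the limit, and so does one other of the three values shown (the limit of > 100000 nM in this assay, at which 2 of the 3 values shown sit). Within the data shown here, the single step that bears on the question runs an at least 1.3-fold lower number from compound 2 to compound 3 (0.12 log units; that floor lies within the scatter); because its floor lies within the scatter, it gives no firm direction. Compound 4 `CCN1CCN(c2nc(Nc3ccc(C#N)c(C(F)(F)F)c3)nc(Oc3ccnc4ccccc34)n2)CC1` differs from compound 2 by hydrogen in place of methyl on a saturated chain carbon bound to an amine nitrogen in a ring and a saturated chain carbon. Among the measured compounds shown here, the one measured step touches the same amine nitrogen in a ring but swaps in an acetyl, a different kind of change, so it offers only loose guidance. With compound 2 at the limit and compound 3 barely below it, the expectation for compound 4 is a step of a number no higher from compound 2 to compound 4 (the limit leaves the size open), that is, essentially none beyond the scatter. Compound 4 is thus estimated at 100000 nM, with a range from 50000 nM to 300000 nM, and most likely only a limit will be reported.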

Compound 4, concentration for 50% growth inhibition: 86600 nM
Compound 4: middle estimate off by 1.2-fold (0.06 log units), on the high side, within the range that was stated.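

With ethyl on the amine nitrogen in a ring, the series gives a measured number in this assay rather than a limit, but the step is an at least 1.1-fold lower number from compound 2 to compound 4 (0.06 log units; that floor lies within the scatter), so trimming isopropyl to ethyl shows no firm direction. Methyl in place of 2,3,4-trimethoxyphenyl on the saturated chain carbon is no more decisive, with an at least 1.1-fold lower number from compound 1 to compound 4 (0.06 log units; that floor lies within the scatter). Ethyl and acetyl on this nitrogen cannot be told apart, at a 1.2-fold higher number from compound 3 to compound 4 (0.06 log units; within the scatter), and part of the series still gives no number to compare: the limit of > 100000 nM in this assay, at which 2 of the 4 values shown sit.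

The compounds shown leave open whether any group on this nitrogen can move the number beyond the scatter, such as a hydroxyethyl chain, a longer chain ending in an amine, or a carboxylic acid. They also leave open whether changes elsewhere on the shared core would do more.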